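Swapping an aryl for a sulfonylpyrrolidinyl on the core

The compounds below may be only part of what the source reports. "The series", "measured", "known", "first", "only" and "open" are said of these compounds alone.

Compound 1 `CC(=O)Nc1cccc(-n2c(Nc3ccc(F)cc3)nc3cnc(Nc4ccc(N5CCN(C)CC5)cc4)nc32)c1` is the more potent of the two measured compounds. In a functional assay on HCC827 cells (Homo sapiens) for antiproliferative activity, read by MTT assay, with a stated time of 72 h (a higher number here means a weaker inhibitor, a lower number a stronger inhibitor), compound 1 gives 10 nM, the lowest of the two numbers recorded. Compound 2 `CC(=O)N1CC[C@H](n2c(Nc3ccccc3)nc3cnc(Nc4ccc(N5CCN(C)CC5)cc4)nc32)C1` carries an acetylpyrrolidinyl group on the aromatic nitrogen and a phenylamino group without fluorine; in this assay compound 2 gives 260 nM, a number far higher than that of compound 1 and beyond the usual scatter.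

Compound 3 `CN1CCN(c2ccc(Nc3ncc4nc(Nc5ccc(F)cc5)n([C@@H]5CCN(S(=O)(=O)C6CC6)C5)c4n3)cc2)CC1` is the compound now to be measured. Relative to compound 1 the change is 1-(cyclopropylsulfonyl)pyrrolidin-3-yl in place of 3-acetamidophenyl on an aromatic nitrogen. Compound 3 thus keeps the (4-fluorophenyl)amino group of compound 1 while placing a saturated pyrrolidinyl group, as compound 2 does, on the aromatic nitrogen of the shared core.

Among the measured compounds shown here, no step between measured compounds covers this change. Since compound 2, which also bears a pyrrolidinyl group there, gives 260 nM, the step of a 9.0-fold higher number from compound 1 to compound 3 (0.95 log units; beyond the scatter) is expected to go toward weaker inhibition and to exceed the scatter. Compound 3 is estimated to give 90 nM in this assay, with a likely range from 25 nM to 400 nM.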

Compound 3, half-maximal inhibitory concentration: 2.5 nM
Beside the measured number, compound 3's estimate is 36-fold (1.56 log units) above it; measured number outside the range, below it.
By their numbers in this assay, from the lowest: compound 3; then compound 1; then compound 2.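

Replacing 3-acetamidophenyl with 1-(cyclopropylsulfonyl)pyrrolidin-3-yl on the aromatic nitrogen gives a 4.0-fold lower number from compound 1 to compound 3 (0.60 log units; beyond the scatter) in this assay, so in this pair the position accepts a group with no six-membered aromatic ring and no hydrogen-bond donor, and the number still falls. Compound 2 also carries a pyrrolidinyl group at this place, but it differs from compound 3 in more than one place, so its higher number says nothing about the pyrrolidinyl group taken alone. Nothing measured here accounts for the lower number of compound 3.

On these data alone, it remains open how much of the step belongs to the saturated pyrrolidinyl ring and how much to the cyclopropylsulfonyl group on its nitrogen, and whether the defined stereocentre of compound 3 matters. Also open, as far as these compounds go, is how an acetyl or a methylsulfonyl group on the pyrrolidine nitrogen would compare with the cyclopropylsulfonyl group with the (4-fluorophenyl)amino group kept, and what a six-membered piperidin-3-yl ring would do in place of the pyrrolidin-3-yl ring.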